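Adenosine receptor A3 series: aryl group on the alkyne

The source may report more compounds than this note shows. Statements on the series, on what has been measured and on what is new or still open speak of the compounds shown alone.

Measured so far, in an assay on CHO cells for displacement of a labelled ligand from adenosine receptor A3 (Homo sapiens), read by scintillation counting, with a stated time of 60 min; a higher number here means a weaker inhibitor, a lower number a stronger inhibitor:
compound 1 `CNC(=O)[C@@]12C[C@@H]1[C@@H](n1cnc3c(NC)nc(C#Cc4ccc(OC)cc4)nc31)[C@H](O)[C@@H]2O` gives 0.63 nM
compound 2 `CNC(=O)[C@@]12C[C@@H]1[C@@H](n1cnc3c(NC)nc(C#Cc4cccnc4)nc31)[C@H](O)[C@@H]2O` gives 2.15 nM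
compound 3 `CCc1ccc(C#Cc2nc(NC)c3ncn([C@H]4[C@H](O)[C@H](O)[C@]5(C(=O)NC)C[C@H]45)c3n2)o1` gives 1.5 nM

Compound 2 has the highest number of the three; its nearest neighbour is compound 3, and the gap to compound 1 is the widest, as a 3.4-fold higher number from compound 1 to compound 2 (0.53 log units; beyond the scatter) shows. Compound 4 `CNC(=O)[C@@]12C[C@@H]1[C@@H](n1cnc3c(NC)nc(C#Cc4cc5ccccc5o4)nc31)[C@H](O)[C@@H]2O` is not yet measured; it differs from compound 2 by 1-benzofuran-2-yl in place of pyridin-3-yl on a triple-bonded carbon.

For the measured compounds named here, two measured steps bear on this change, both swapping the aryl group on the triple-bonded carbon of the shared core: a 3.4-fold higher number from compound 1 to compound 2 (0.53 log units; beyond the scatter) and a 1.4-fold lower number from compound 2 to compound 3 (0.16 log units; within the scatter). Replacing pyridin-3-yl by an aryl without nitrogen gave a lower number in one case beyond the scatter and in the other within it. For compound 4 a modest step to a lower number is therefore expected, of about the size seen between compound 2 and compound 3, possibly approaching that of compound 1. The expected step is a 2.2-fold lower number from compound 2 to compound 4 (0.33 log units; beyond the scatter). Compound 4 is estimated at 1 nM with a range from 0.4 nM to 3 nM.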

Compound 4, inhibition constant: 1.62 nM
For compound 4 the middle estimate is 1.6-fold (0.21 log units) below the measured one, and the stated range covers the measured number.
By their numbers in this assay, from the lowest: compound 1; then compounds 3, 4 and 2 (each within the scatter of the next).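

In this assay, a second aromatic ring on the triple-bonded carbon does not set 1-benzofuran-2-yl apart from the single-ring groups: the change gives a 1.3-fold lower number from compound 2 to compound 4 (0.12 log units; within the scatter), and the comparison with 5-ethylfuran-2-yl gives a 1.1-fold higher number from compound 3 to compound 4 (0.03 log units; within the scatter). Removing the pyridine nitrogen is therefore not enough on its own to produce a step beyond the scatter, and compound 1 remains the exception, with a 2.6-fold higher number from compound 1 to compound 4 (0.41 log units; beyond the scatter). Pyridin-3-yl, 5-ethylfuran-2-yl and 1-benzofuran-2-yl cannot be told apart at this position, while 4-methoxyphenyl stands apart from all three. No supporting data explain these steps.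

On these data alone, it remains open whether the lower number of compound 1 depends on its methoxy group. Plain phenyl, 4-aminophenyl or 4-carboxyphenyl on the triple-bonded carbon would address this.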